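Phenol Enters Where Two Analogues Reached Only a Limit

A few compounds are considered here, and "the series" means these few. Any claim that something is new, unique, unknown or untested is made for them only; others in the source may bear on it.

Compound 1 `COc1cccc(/C=C2\CCC/C(=C\c3ccc(Br)cc3)C2=O)c1OC` in a functional assay on A549 cells (Homo sapiens) for cytotoxicity, read by MTT assay, with a stated time of 72 h (a higher number here means a weaker inhibitor, a lower number a stronger inhibitor), gives > 20000 nM, which is a limit of the assay and not a number.
Compound 2 `COc1ccc(/C=C2\CCC/C(=C\c3cccc(OC)c3OC)C2=O)cc1` in this assay gives > 20000 nM, likewise a limit of the assay.

Compound 2 therefore stands at a limit in this assay, and no number places it against anything else. Within the data shown here, the only measured step, a step that the two limits leave unreadable from compound 1 to compound 2, is methoxy in place of bromo on an aromatic carbon; its size cannot be read because of the limit of > 20000 nM in this assay, at which 2 of the 2 values shown sit.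

Compound 3 `COc1cc(/C=C2\CCC/C(=C\c3cccc(OC)c3OC)C2=O)ccc1O` differs from compound 2 by 4-hydroxy-3-methoxyphenyl in place of 4-methoxyphenyl on a double-bonded chain carbon bound to a double-bonded ring carbon. Among the measured compounds shown here, no measured step touches a change of this kind, and the one step available gives no readable size, so nothing in the data sets a direction for compound 3 in this assay. The step meant by the estimate, a number no higher from compound 2 to compound 3 (the limit leaves the size open), is expected to lie within the usual scatter, with the most likely outcome once more a limit rather than a number. For compound 3 the estimated value in this assay is 20000 nM, with a range from 8000 nM to 50000 nM.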

Compound 3, half-maximal inhibitory concentration: > 20000 nM
Compound 3 gave a limit, no number; the forecaster's own chance of this, stated with the estimate: 75%; the middle value lies on the limit itself.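

No new step can be read for compound 1, compound 2 and compound 3, because each of them gives only a limit of the assay and not a number: the limit of > 20000 nM in this assay, at which 3 of the 3 values shown sit.

The compounds shown leave open whether 4-hydroxy-3-methoxyphenyl, 4-methoxyphenyl or 4-bromophenyl on the shared core makes any difference in this assay.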